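The compounds below may be only part of what the source reports. "The series", "measured", "known", "first", "only" and "open" are said of these compounds alone.

Measured compounds:
- compound 1, `C=C(Br)C(=O)Nc1cccc(-c2cn3nc(Cc4ccc(Cl)cc4)sc3n2)c1`, gives 1100 nM
- compound 2, `Nc1cccc(-c2cn3nc(Cc4ccc(Cl)cc4)sc3n2)c1`, gives 6000 nM
- compound 3, `C=C(Br)C(=O)Nc1cccc(-c2cn3c(-c4ccc(Cl)cc4)csc3n2)c1`, gives 1100 nM

All three values come from a functional assay on FM3A cells (Mus musculus) for inhibition, read by cell counting, with a stated time of 2 days; a lower number here means a stronger inhibitor, a higher number a weaker inhibitor. Compound 1 stands level with compound 3 at the digits printed, the two together giving the lowest numbers of the three; compound 2 lies furthest away. Among the compounds with values here, the only step between neighbours that differ in one place is a 5.5-fold higher number from compound 1 to compound 2 (0.74 log units; beyond the scatter), which shows that removing the (1-bromoethenyl)carbonyl group costs a moderate amount of inhibition.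

Compound 4, `C=C(Br)C(=O)Nc1cccc(-c2cn3nc(-c4ccc(OC)cc4)sc3n2)c1`, is not yet measured. It differs from compound 1 as follows: 4-methoxyphenyl in place of 4-chlorobenzyl on an aromatic carbon. Within the data shown here, no measured pair shows this change, so nothing in the data tells how the assay responds to it. Compound 3 differs from compound 1 in a different way, and its value being level with compound 1 only shows that the core tolerates at least one rearrangement of its side group without a shift beyond the scatter. Among the measured compounds shown here, no step bears on the change directly, so a modest change in either direction is plausible; the expectation is a small step of a 1.8-fold higher number from compound 1 to compound 4 (0.26 log units; within the scatter), and the estimate for compound 4 in this assay is 2000 nM, with a range from 600 nM to 7000 nM.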

Compound 4, half-maximal inhibitory concentration: 890 nM
The estimate for compound 4 lay 2.2-fold (0.35 log units) above the measured number; measured number inside the range.
By their numbers in this assay, from the lowest: compounds 4, 1 and 3 (each within the scatter of the next); then compound 2.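

In this assay, putting 4-methoxyphenyl in place of 4-chlorobenzyl gives a 1.2-fold lower number from compound 1 to compound 4 (0.09 log units; within the scatter), so this exchange leaves the inhibition unchanged within the scatter. Within the data shown here, this is the first direct look at this aromatic carbon of the five-membered ring with 2 nitrogen and 1 sulfur, and it shows that the group there can be altered in more than one way at once without a shift beyond the scatter: the chlorine leaves, an oxygen and one hydrogen-bond acceptor enter, and the carbon that links the benzyl ring to the core is gone, while the count of heavy atoms stays the same. Nothing at hand explains why the number holds steady, and these changes cannot be told apart from this one pair.

On these data alone, it remains open how a much smaller or charged group at this place, such as an amine or a carboxylic acid, would fare, and whether a plain phenyl or a 4-chlorophenyl would match these values. As far as these compounds go, it is also open whether removing the (1-bromoethenyl)carbonyl group from compound 4 would cost as much as a 5.5-fold higher number from compound 1 to compound 2 (0.74 log units; beyond the scatter).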